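The source may report more compounds than this note shows. Statements on the series, on what has been measured and on what is new or still open speak of the compounds shown alone.

Measured compounds:
compound 1, `CCOc1ccc(-c2nn(-c3ccccc3)cc2C2=NOC3C(=O)N(c4ccccc4)C(=O)C23)cc1`, 12.2%
compound 2, `CCOC(=O)c1onc(-c2cn(-c3ccccc3)nc2-c2ccc(Cl)cc2)c1C(=O)OCC`, 17.3%
compound 3, `Brc1ccc(-c2nn(-c3ccccc3)cc2-c2cc(-c3ccccc3)on2)cc1`, 14.5%

Of the compounds shown here, three have been measured in a functional assay on the whole organism (Abdomen, strain Swiss albino) with Mus musculus as the target, with stated times of 10 min and 5 min, at a dose of 15 mg/kg by the oral route; a higher number here means a stronger effect of the compound at the dose given, a lower number a weaker effect. Compound 1 gives 12.2%, compound 2 gives 17.3%, and compound 3 gives 14.5%. Among the measured compounds shown here, no two of them differ by a single change of structure, so no step between them can be drawn; what the numbers show is that all three sit close together, with the gap from compound 3 to compound 1 and the gap from compound 3 to compound 2 both within the scatter of repeated measurements.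

Compound 4, `COc1ccc(-c2nn(-c3ccccc3)cc2-c2cc(-c3ccccc3)on2)cc1`, has not yet been measured. It differs from compound 3 in one place: methoxy in place of bromo on an aromatic carbon. The rest of the structure is unchanged. For the measured compounds named here, with no comparable step among the measured compounds to guide the expectation, and all three measured values lying within the scatter of one another, the step expected in this assay from compound 3 to compound 4 is a number 0.5 percentage points lower from compound 3 to compound 4 (within the scatter), none beyond the scatter. Compound 4 is therefore expected to give about 14%, within a range of 5% to 24%.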

Compound 4, a percentage reported as activity, at one dose (the size of the read-out at that dose, not a potency): 11.8%
Estimate against measurement, compound 4: 2.2 percentage points above; low and high end bracket the measured number.
By their numbers in this assay, from the lowest: compounds 4, 1, 3 and 2 (each within the scatter of the next).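

Among the compounds shown here, compound 3 and compound 4 form the first pair that differs in one place, so the aromatic carbon para to a large group can now be read directly. In this assay, methoxy in place of bromo gives a number 2.7 percentage points lower from compound 3 to compound 4 (within the scatter) and so shows no effect beyond the scatter, even though the exchange adds a hydrogen-bond acceptor and replaces a single bromine with a two-atom group. No measurement on hand offers an explanation for this result.

Going by these compounds, whether an amine, a hydroxy group or a carboxylic acid at this place would shift the read-out beyond the scatter remains open. On these data alone, it is also open whether the same exchange would leave the read-out unmoved on a different core, or at another dose.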